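From cycloheptyl to cyclohexylmethyl on the amide nitrogen

A few compounds are considered here, and "the series" means these few. Any claim that something is new, unique, unknown or untested is made for them only; others in the source may bear on it.

Two compounds on the shared core have entries so far. For compound 1 `Cc1cc(C)c2cc(C(=O)NC3CCN(C)CC3)[nH]c2c1`, the entry in an ADME assay on Vero cells (Chlorocebus sabaeus) for cytotoxicity, read by resazurin assay (on this read-out lower numbers stand for stronger inhibition and higher numbers for weaker inhibition), reads "not determined" (no result reported), so it provides no comparison.

In this assay, compound 2 `Cc1cc(C)c2cc(C(=O)NC3CCCCCC3)[nH]c2c1` gives > 200000 nM, which is a limit of the assay and not a number. Going by the values given here, its position therefore has no exact value, and the only evidence available is the limit of > 200000 nM in this assay, at which 1 of the 2 values shown sits.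

Compound 3 `Cc1cc(C)c2cc(C(=O)NCC3CCCCC3)[nH]c2c1` has cyclohexylmethyl in place of cycloheptyl on an amide-type nitrogen. The two compounds have the same atoms, joined differently.

Among the compounds with values here, no measured step gauges such a change. The expectation rests on compound 2 alone, at > 200000 nM, again a limit. The estimated change, a number no higher from compound 2 to compound 3 (the limit leaves the size open), is expected to stay within the usual scatter of this assay, with no direction favoured. A report of compound 3 as a limit only is more likely than not.

For compound 3 the estimated value is 200000 nM, with an expected range from 80000 nM to 400000 nM.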

Compound 3, half-maximal inhibitory concentration: > 200000 nM
Compound 3: no number, only a limit; the forecaster's own chance of this, stated with the estimate: 60%; the middle value lies on the limit itself.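

Going by these compounds alone, compound 2 and compound 3 are both reported only as limits in this assay, not as numbers, so no step between them can be read. The compounds shown leave open where the exact value of either compound lies, and whether cyclohexylmethyl in place of cycloheptyl on an amide-type nitrogen shifts it at all.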